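A few compounds are considered here, and "the series" means these few. Any claim that something is new, unique, unknown or untested is made for them only; others in the source may bear on it.

Measured so far: compound 1 `CCOc1ccc(CNC(=O)c2ccc(C(C)(C)C)cc2)cc1` with 160 nM; compound 2 `CC(C)(C)c1ccc(C(=O)NCc2ccc(NC(=O)C(F)(F)F)cc2Cl)cc1` with 14 nM; compound 3 `CC(C)(C)c1ccc(C(=O)NCc2ccc(C(=O)O)cc2Cl)cc1` with 7500 nM.

These values come from an assay on HeLa cells with Bile acid receptor (Homo sapiens) as the target, read by a luciferase reporter, with a stated time of 24 h; a lower number here means that less compound is needed, a higher number that more compound is needed for the effect. Compound 1 stands second highest of the three, between compound 2 below and compound 3 well above. Compound 4 `CC(C)(C)c1ccc(C(=O)NCc2ccc(NS(C)(=O)=O)cc2)cc1` differs from compound 1 by methanesulfonamido in place of ethoxy on an aromatic carbon. For the measured compounds named here, no measured step covers this exact change. Going by the values given here, the one measured step, a 540-fold higher number from compound 2 to compound 3 (2.73 log units; beyond the scatter), shows that a carboxy group there does far worse than a group carrying a hydrogen-bond donor, as compound 2 does. Since the entering group also brings a hydrogen-bond donor, compound 4 is expected to move toward compound 2, giving a 2.7-fold lower number from compound 1 to compound 4 (0.43 log units; beyond the scatter). Compound 4 is therefore estimated at 60 nM, within 12 nM to 300 nM.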

Compound 4, half-maximal effective concentration: 44 nM
Compound 4: middle estimate off by 1.4-fold (0.13 log units), on the high side; the measured number falls inside the stated range.
By their numbers in this assay, from the lowest: compound 2; then compound 4; then compound 1; then compound 3.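

On an aromatic carbon para to a large group, methanesulfonamido in place of ethoxy gives a 3.6-fold lower number from compound 1 to compound 4 (0.56 log units; beyond the scatter) in this assay. This shows that a larger group with a hydrogen-bond donor can lower the number on a ring without the chlorine of compound 2 and compound 3, whereas the earlier step compared two groups on a chlorine-bearing ring. No measurement here explains why the number falls with this change.

As far as these compounds go, whether the hydrogen-bond donor itself matters remains open. A plain amine or an N-methylated methanesulfonamido group at this position could help test that.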